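Trimming the ester-bearing chain on the ring amine

A few compounds are considered here, and "the series" means these few. Any claim that something is new, unique, unknown or untested is made for them only; others in the source may bear on it.

Measured so far in a functional assay (strain AB) with Danio rerio as the target, read by microscopy, with a stated time of 1 h; a lower number here means that less compound is needed, a higher number that more compound is needed for the effect:
Compound 1, `CC(C)(C)OC(=O)CCCC[N+]1(C)CCc2c(sc(NC(=O)Nc3ccc(Cl)cc3)c2C(N)=O)C1`, gives 140 nM.
Compound 2, `CCN1CCc2c(sc(NC(=O)C3(c4ccc(Cl)cc4)CC3)c2C(N)=O)C1`, gives > 25000 nM, which is a limit of the assay and not a number.
Compound 3, `CCN1CCc2c(sc(NC(=O)Nc3ccc(Cl)cc3)c2C(=O)OC)C1`, gives > 25000 nM, likewise a limit of the assay.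

Among the measured compounds shown here, compound 1 thus holds the only number among the three values shown; the other two sit at the limit of > 25000 nM in this assay, at which 2 of the 3 values shown sit. For the measured compounds named here, no two measured compounds differ in just one place, so no measured step is available for comparison.

Compound 4, `CC[N+]1(C)CCc2c(sc(NC(=O)Nc3ccc(Cl)cc3)c2C(N)=O)C1`, is still to be measured in this assay. It differs from compound 1 by hydrogen in place of 2-(tert-butoxycarbonyl)ethyl on a saturated chain carbon, two bonds along the chain from an amine nitrogen in a ring. Without a measured step of this kind, the size of the change is uncertain; the expectation is a moderate step from compound 1 to compound 4 toward more compound being needed, a 2.9-fold higher number from compound 1 to compound 4 (0.46 log units; beyond the scatter), with the possibility of no change beyond the scatter. Compound 4 is estimated at 400 nM, expected between 90 nM and 3000 nM.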

Compound 4, half-maximal effective concentration: 1960 nM
For compound 4 the middle estimate is 4.9-fold (0.69 log units) below the measured one; the range from low to high includes it.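

In this assay, among the compounds shown here, hydrogen in place of 2-(tert-butoxycarbonyl)ethyl on a saturated chain carbon, two bonds along the chain from an amine nitrogen in a ring, gives a 14-fold higher number from compound 1 to compound 4 (1.15 log units; beyond the scatter), the first measured step. The ester-bearing chain is thus not required for a measurable value, since compound 4 still gives a number, but its loss counts well beyond the scatter. Nothing measured here gives a cause for this step.

As far as these compounds go, it remains open whether the step follows the tert-butyl ester or the chain length. A carboxylic acid at the chain end, or a plain pentyl chain, would separate the two.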